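The source may hold more compounds than are shown below. What is called first, only, known or untested is meant among the compounds shown, and "the series" means these compounds.

Measured in a functional assay on HT-29 cells (Homo sapiens) for antiproliferative activity, read by sulforhodamine B assay, with a stated time of 48 h; a higher number here means a weaker inhibitor, a lower number a stronger inhibitor:
- compound 1 `CCc1ccccc1NS(=O)(=O)c1ccc(N2CCNC2=O)cc1`: 240 nM
- compound 2 `Cc1ccc(NS(=O)(=O)c2ccc(N3CCNC3=O)cc2)cc1C`: 230 nM
- compound 3 `Cc1cc(C)cc(NS(=O)(=O)c2ccc(N3CCNC3=O)cc2)c1`: 82 nM

Compound 3 has the lowest number of the three and is the strongest inhibitor in the set, clear of both others by more than the scatter. Compound 4 `O=C1NCCN1c1ccc(S(=O)(=O)Nc2cccc(Cl)c2)cc1` has 3-chlorophenyl in place of 3,5-dimethylphenyl on a sulfonamide nitrogen.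

Going by the values given here, no measured compound carries a chlorine, so the closest guides are the two steps that arrive at the 3,5-dimethylphenyl group: a 2.9-fold lower number from compound 1 to compound 3 (0.47 log units; beyond the scatter) and a 2.8-fold lower number from compound 2 to compound 3 (0.45 log units; beyond the scatter). Both are modest, and both favour compound 3. The step of a 1.0-fold lower number from compound 1 to compound 2 (0.02 log units; within the scatter) shows two other substituted phenyl groups that do not differ beyond the scatter. In this assay, a modest move away from compound 3 towards a higher number is therefore expected, though a result close to compound 3 remains possible. The expected step is a 2.1-fold higher number from compound 3 to compound 4 (0.32 log units; beyond the scatter). For compound 4 the estimated value is 170 nM, with an expected range of 60 nM to 450 nM.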

Compound 4, half-maximal inhibitory concentration: 55 nM
Beside the measured number, compound 4's estimate is 3.1-fold (0.49 log units) above it, and the stated range ends above it.
By their numbers in this assay, from the lowest: compounds 4 and 3 (each within the scatter of the next); then compounds 2 and 1 (each within the scatter of the next).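

In this assay, a 1.5-fold lower number from compound 3 to compound 4 (0.17 log units; within the scatter) shows that on the sulfonamide nitrogen a 3-chlorophenyl group cannot be told apart from the 3,5-dimethylphenyl group, so a ring bearing a chlorine and no methyl group still gives a number in the same range. With a 4.2-fold lower number from compound 2 to compound 4 (0.62 log units; beyond the scatter) and a 4.4-fold lower number from compound 1 to compound 4 (0.64 log units; beyond the scatter), the 3-chlorophenyl group also stands clear of the 3,4-dimethylphenyl and 2-ethylphenyl groups, so the low numbers at this position are not confined to the 3,5-dimethylphenyl group. Nothing available explains why these groups read as they do.

The compounds shown leave open how a phenyl ring carrying a methoxy group, an amine or a carboxylic acid would read here. They also leave open whether a second chlorine on the ring would change the number.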